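Swapping chloro for fluoro on a triazole benzofuran aromatase inhibitor

The source may hold more compounds than are shown below. What is called first, only, known or untested is meant among the compounds shown, and "the series" means these compounds.

Of the compounds shown here, three sharing one core have been measured in an assay on JEG-3 cells for inhibition of Aromatase (Homo sapiens), with a stated time of 1 h; on this read-out lower numbers stand for stronger inhibition and higher numbers for weaker inhibition. Compound 1 `Oc1ccc2cc(C(c3ccc(F)cc3)n3cncn3)oc2c1` gives 0.39 nM. Compound 2 `CC#CCOc1ccc2cc(C(c3ccc(Cl)cc3)n3cncn3)oc2c1` gives 0.53 nM. Compound 3 `CCOc1ccc2cc(C(c3ccc(Cl)cc3)n3cncn3)oc2c1` gives 0.46 nM. Compound 2 stands at the highest of the three numbers, but its gap to compound 3 is a step of a 1.2-fold lower number from compound 2 to compound 3 (0.06 log units; within the scatter), and its gap to compound 1 is also within the scatter, so the three cannot be ordered.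

The new compound 4 `CC#CCOc1ccc2cc(C(c3ccc(F)cc3)n3cncn3)oc2c1` differs from compound 2 in one place: fluoro in place of chloro on an aromatic carbon.

Going by the values given here, no measured step changes this halogen alone. Among the compounds with values here, the only measured step, from compound 2 to compound 3, alters the chain on the oxygen and is within the scatter. Compound 1 carries fluoro and compound 3 carries chloro, yet they also differ at the oxygen, so their values show only that both halogens sit with strong inhibition. From this, no step beyond the scatter is expected in this assay from compound 2 to compound 4.

Compound 4 is therefore expected to give about 0.45 nM, with a range from 0.2 nM to 1 nM, a step of a 1.2-fold lower number from compound 2 to compound 4 (0.07 log units; within the scatter).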

Compound 4, half-maximal inhibitory concentration: 4.1 nM
Estimate against measurement, compound 4: 9.1-fold (0.96 log units) below; measured number outside the range, above it.
By their numbers in this assay, from the lowest: compounds 1, 3 and 2 (each within the scatter of the next); then compound 4.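

In this assay, going by these compounds alone, the change from 4-chlorophenyl to 4-fluorophenyl can now be read on its own for the first time, and with the but-2-yn-1-yl chain on the oxygen it is not a silent swap: the halogen alone gives a 7.7-fold higher number from compound 2 to compound 4 (0.89 log units; beyond the scatter), even though only one heavy atom is exchanged for another. Within the data shown here, the oxygen matters too when fluoro is held in place, with an 11-fold higher number from compound 1 to compound 4 (1.02 log units; beyond the scatter), whereas the one step at that oxygen with chloro, a 1.2-fold lower number from compound 2 to compound 3 (0.06 log units; within the scatter), stays within the scatter, so a change at the oxygen can be harmless in one pair of compounds and costly in another. Nothing available here accounts for why the number rises with either new step.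

The compounds shown leave open whether the halogen swap would cost as much with hydrogen or the chain of compound 3 on the oxygen, so it remains unclear whether the halogen and the oxygen chain act independently. On these data alone, it is also open how a bromo group or a nitrile would behave at the place para to the large group, which would show whether chloro is unusual or fluoro is.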